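Chloro removal on the aminopyridine arm of compound 1

The source may report more compounds than this note shows. Statements on the series, on what has been measured and on what is new or still open speak of the compounds shown alone.

Measured so far:
compound 1 `Clc1cccc(NCc2ccc(CNc3ncccn3)cc2)n1` gives 1 nM
compound 2 `Fc1ccc(NCc2ccc(CNc3ccc(F)cn3)cc2)nc1` gives 100 nM

Both values come from an assay on MDA-MB-231 cells for displacement of a labelled ligand from C-X-C chemokine receptor type 4 (Homo sapiens); on this read-out higher numbers stand for an effect only at larger amounts of compound and lower numbers for an effect already at smaller amounts. Within the data shown here, compound 1 holds the lowest number of the two; compound 2 sits a long way above it, and the two compounds differ at several places, so no single step connects them and nothing beyond the two numbers themselves can be read from the pair.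

Compound 3 `c1ccc(NCc2ccc(CNc3ncccn3)cc2)nc1` has not been measured. It differs from compound 1 by hydrogen in place of chloro on an aromatic carbon, the larger reading being 6-chloropyridin-2-yl to pyridin-2-yl. Among the measured compounds shown here, no measured pair shows this exact change. For the measured compounds named here, the step from compound 1 to compound 3 is expected to move the number upward by a 10-fold higher number from compound 1 to compound 3 (1.00 log units; beyond the scatter), beyond the scatter, since the only compound without a substituent on that ring position among the two measured, compound 2, carries a different pattern altogether and gives 100 nM. Compound 3 is therefore estimated at 10 nM, with a range from 2 nM to 60 nM, in this assay .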

Compound 3, effective concentration (reported as EC, without a stated level of effect): 100 nM
Compound 3: middle estimate off by 10-fold (1.00 log units), on the low side; measured number above the stated range.
By their numbers in this assay, from the lowest: compound 1; then compounds 2 and 3 (each within the scatter of the next).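

In this assay, among these compounds, the change from 6-chloropyridin-2-yl to pyridin-2-yl gives the first single-place comparison: a 100-fold higher number from compound 1 to compound 3 (2.00 log units; beyond the scatter), a large step beyond the scatter. Only the chloro leaves, and the rest of the core of compound 1 stays as it was, so the gap in this pair belongs to this one position, on an aromatic carbon next to the ring nitrogen. No measurement on hand accounts for the size of the step.

Only chloro and hydrogen are shown at this position, so it remains open whether the low number of compound 1 is specific to chloro or would also hold with a bromo, methyl or methoxy group there. The change is also seen only once, leaving open whether the loss of chloro would give a step of similar size with another group, such as a 5-fluoropyridin-2-yl ring, on the other arm of the core.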